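The source may hold more compounds than are shown below. What is called first, only, known or untested is meant among the compounds shown, and "the series" means these compounds.

In an ADME assay on HUVEC cells (Homo sapiens) for inhibition, read by MTT assay, with a stated time of 48 h (a higher number here means a weaker inhibitor, a lower number a stronger inhibitor), compound 1 `COc1ccccc1-c1csc(N/N=C/c2cc(OC)c(OC)c(Br)c2Br)n1` gives > 100000 nM, a limit of the assay rather than a number. Compound 2 `COc1ccccc1-c1csc(N/N=C/c2cc(Br)c(OC)c(OC)c2)n1` likewise gives > 100000 nM, again a limit. The step that the two limits leave unreadable from compound 1 to compound 2 is therefore unreadable, both values sitting at the limit of > 100000 nM in this assay, at which 2 of the 2 values shown sit. Compound 2 thus stands only at a limit, with no numbered value in the series. Compound 3 `COc1cc(/C=N/Nc2nc(-c3cccc(Br)c3)cs2)cc(Br)c1OC` differs from compound 2 by 3-bromophenyl in place of 2-methoxyphenyl on an aromatic carbon. Within the data shown here, no measured step bears on this change, and the one step known is unreadable. Compound 3 is expected at 150000 nM, with a range from 40000 nM to 600000 nM. The expected step that the limit leaves unreadable from compound 2 to compound 3 is estimated as none beyond the scatter, most likely another limit.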

Compound 3, half-maximal inhibitory concentration: > 100000 nM
Compound 3: only a limit was reported; the forecaster's own chance of this, stated with the estimate: 80%; the middle value does not contradict the limit.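

No step can be read between compound 2 and compound 3, both values being limits of the assay. Still open is whether any change on the shared core gives a numbered value in this assay, all compounds shown sitting at one limit: the limit of > 100000 nM in this assay, at which 3 of the 3 values shown sit.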